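The source may hold more compounds than are shown below. What is called first, only, known or untested is meant among the compounds shown, and "the series" means these compounds.

Among the measured compounds shown here, compound 2 `CC(Cc1ccc(NCc2cccc(Oc3ccccc3)c2)cc1)C(=O)O` stands at the lowest of the two numbers so far in a functional assay on CHO cells for agonist activity at Free fatty acid receptor 1 (Homo sapiens) (a higher number here means that more compound is needed for the effect, a lower number that less compound is needed), where compound 2 gives 100 nM. For the measured compounds named here, compound 1 `O=C(O)/C=C/c1ccc(NCc2cccc(Oc3ccccc3)c2)cc1` gives 145 nM in this assay, and the step of a 1.5-fold lower number from compound 1 to compound 2 (0.16 log units; within the scatter) was the only change at the carboxylic chain measured so far. Compound 3 `CC(CC(=O)O)c1ccc(NCc2cccc(Oc3ccccc3)c2)cc1` has not yet been measured; it differs from compound 2 by 1-(carboxymethyl)ethyl in place of 2-carboxypropyl on an aromatic carbon. The step from compound 1 to compound 2 is the one that bears on this change, since it too altered the chain at that place, and it stayed within the scatter. The account therefore expects for compound 3 a step of a 1.5-fold higher number from compound 2 to compound 3 (0.18 log units; within the scatter) in this assay, not clearly beyond the scatter in either direction. The estimate for compound 3 in this assay is 150 nM, with a range from 50 nM to 450 nM.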

Compound 3, half-maximal effective concentration: 126 nM
For compound 3 the middle estimate is 1.2-fold (0.08 log units) above the measured one; the range from low to high includes it.
By their numbers in this assay, from the lowest: compounds 2, 3 and 1 (each within the scatter of the next).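

In this assay, 1-(carboxymethyl)ethyl in place of 2-carboxypropyl on the aromatic carbon gives a 1.3-fold higher number from compound 2 to compound 3 (0.10 log units; within the scatter), so joining the same atoms differently at this position leaves the number within the scatter. Against 2-carboxyethenyl, the same chain gives a 1.2-fold lower number from compound 1 to compound 3 (0.06 log units; within the scatter), which extends to a third chain what the earlier pair had shown for 2-carboxypropyl alone: all three chains at this place read alike. Nothing measured here gives a reason for this.

The compounds shown leave open whether a longer chain at this position, or a tetrazole or an amide in place of the carboxylic acid, would also stay within the scatter. They also leave open whether the separate mirror-image forms of compound 2 or of compound 3 would differ from each other.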